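The source may hold more compounds than are shown below. What is called first, only, known or untested is meant among the compounds shown, and "the series" means these compounds.

Measured in a functional assay on MCF7 cells (Homo sapiens) for inhibition, read by MTT assay, with a stated time of 72 h; on this read-out lower numbers stand for stronger inhibition and higher numbers for weaker inhibition:
compound 1 `Cn1ccc2c(Oc3ccc(NC(=O)c4cn(-c5ccc(Br)cc5)c5ccccc5c4=O)cc3F)ccnc21` gives 1830 nM
compound 2 `O=C(Nc1ccc(Oc2ccnc3[nH]ccc23)c(F)c1)c1cn(-c2ccccc2)c2ccccc2c1=O` gives 430 nM

Compound 2 stands lowest of the two numbers; compound 1 sits at a higher number, and the gap between the two lies beyond the scatter. Within the data shown here, compound 1 and compound 2 differ from each other in more than one place, so no single step can be read from that pair; the two values show only that the combination of changes separating them goes with a weaker read-out for compound 1.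

Compound 3 `O=C(Nc1ccc(Oc2ccnc3[nH]ccc23)c(F)c1)c1cn(-c2ccc(Br)cc2)c2ccccc2c1=O` is not yet measured in this assay. It differs from compound 2 in one place: bromo in place of hydrogen on an aromatic carbon, the same difference read one bond further out being phenyl to 4-bromophenyl. Among the measured compounds shown here, no measured pair isolates this change, so the direction rests on a guess. Compound 1 carries the same bromo and reads weaker than compound 2, but its other difference is not accounted for. A modest shift toward a higher number is expected, within or just beyond the scatter, as a 1.7-fold higher number from compound 2 to compound 3 (0.24 log units; within the scatter). For compound 3 the estimate is 750 nM, ranging from 250 nM to 2200 nM.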

Compound 3, half-maximal inhibitory concentration: 650 nM
Estimate against measurement, compound 3: 1.2-fold (0.06 log units) above, and the stated range covers the measured number.
By their numbers in this assay, from the lowest: compounds 2 and 3 (each within the scatter of the next); then compound 1.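

In this assay, bromo in place of hydrogen on an aromatic carbon, para to a large group, gives a 1.5-fold higher number from compound 2 to compound 3 (0.18 log units; within the scatter), so phenyl and 4-bromophenyl cannot be told apart at this position on these numbers. Among these compounds, compound 3 also isolates the one remaining difference from compound 1: hydrogen in place of methyl on the aromatic nitrogen gives a 2.8-fold lower number from compound 1 to compound 3 (0.45 log units; beyond the scatter), which places the larger part of the gap between compound 1 and compound 2 at that nitrogen rather than at the bromo. No measurement at hand gives a reason for either step.

Going by these compounds, what a methoxy group, an amine or a carboxylic acid would do at the position para to the large group stays open, as does the effect of a longer chain on the aromatic nitrogen. Also open, on these data alone, is whether the step at that nitrogen would read the same with phenyl in place of 4-bromophenyl, and whether either step carries over to other cell lines.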